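Difluoromethoxy in place of fluoro on compound 3

The source may report more compounds than this note shows. Statements on the series, on what has been measured and on what is new or still open speak of the compounds shown alone.

In a toxicity assay on MDCK cells (Canis lupus familiaris) for cytotoxicity, read by crystal violet staining, with a stated time of 48 h (a lower number here means that less compound is tolerated, a higher number that more compound is tolerated), compound 1 `CCc1ccc2[nH]c(=O)c(CN(Cc3ccc(O)cc3)Cc3ccc(C(C)(C)C)cc3)cc2c1` reads > 10000 nM, which is a limit. Compound 2 `Cc1ccc2[nH]c(=O)c(CN(Cc3ccc(C(C)(C)C)cc3)C(C)c3ccc(F)cc3)cc2c1` reads > 33000 nM, also a limit. Among the compounds with values here, compound 3 `CCc1ccc2[nH]c(=O)c(CN(Cc3ccc(C(C)(C)C)cc3)C(C)c3ccc(F)cc3)cc2c1` gives 2800 nM, the only actual number so far.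

Compound 4 `CCc1ccc2[nH]c(=O)c(CN(Cc3ccc(C(C)(C)C)cc3)C(C)c3ccc(OC(F)F)cc3)cc2c1` carries difluoromethoxy in place of fluoro on an aromatic carbon, para to a large group: difluoromethoxy in place of fluoro on an aromatic carbon.

Within the data shown here, no measured step replaces the fluoro itself, so the evidence is indirect. Exchanging 4-hydroxybenzyl for 1-(4-fluorophenyl)ethyl on an amine nitrogen, the substituent that changes again here, gave an at least 3.5-fold lower number from compound 1 to compound 3 (0.55 log units; beyond the scatter). Methyl in place of hydrogen on a saturated chain carbon gave an at least 11-fold lower number from compound 2 to compound 3 (1.07 log units; beyond the scatter), a large step from a small edit. Both steps start from a limit, so their true sizes are open, and a wide range is warranted.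

No step beyond the scatter is expected in this assay; any drift would more likely be towards a lower number. The estimated step is a 1.3-fold lower number from compound 3 to compound 4 (0.10 log units; within the scatter). For compound 4 the expected value is 2200 nM, with an estimated range of 900 nM to 6000 nM.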

Compound 4, half-maximal cytotoxic concentration: > 5000 nM
Compound 4: no number, only a limit; the forecaster's own chance of this, stated with the estimate: 10%; middle value at least 2.2-fold (0.35 log units) away from the limit.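

In this assay, the first change shown at the aromatic carbon para to a large group, difluoromethoxy in place of fluoro, gives an at least 1.7-fold higher number from compound 3 to compound 4 (0.25 log units; that floor lies within the scatter). The reading for compound 4 is a limit and not a number: the limit of > 5000 nM in this assay, at which 1 of the 4 values shown sits.

This position therefore tolerates the exchange of fluoro for difluoromethoxy with no sign of a lower number, though the floor of the step does not separate the two compounds beyond the scatter.

The step from compound 1 to compound 4 cannot be read, since both values are limits. From the compounds shown here alone, the true value of compound 4 stays open, as does the reading with a methoxy group or a carboxylic acid at this place on the shared core.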